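This account rests on a few compounds, and the source may have more. Where it says the series, first, only, none or still open, it means among the compounds named here.

Of the compounds shown here, three of one shared core have been tested in an ADME assay on Vero cells (Chlorocebus sabaeus) for cytotoxicity, read by MTT assay, with a stated time of 72 h; on this read-out higher numbers stand for lower toxicity in this test and lower numbers for higher toxicity in this test. Compound 1 `COC(=O)c1cc(-c2cccc(NC(=O)c3ccc(/C=C/C(=O)c4ccc(Cl)cc4Cl)cc3)c2)on1` gives > 40 ug/mL, which is a limit of the assay and not a number. Compound 2 `COC(=O)c1cc(-c2cccc(NC(=O)c3ccc(/C=C/C(=O)c4ccccc4C)cc3)c2)on1` gives > 25 ug/mL, again a limit rather than a measured number. Compound 3 `COC(=O)c1cc(-c2cccc(NC(=O)c3ccc(/C=C/C(=O)c4cccc(Br)c4)cc3)c2)on1` gives > 100 ug/mL, also a limit, so compound 3 stands at the highest of the three limits reached here, yet none of the three readings is a true number.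

Because every value is a limit, the steps between the measured compounds cannot be read: a step that the two limits leave unreadable from compound 1 to compound 2, a step that the two limits leave unreadable from compound 1 to compound 3 and a step that the two limits leave unreadable from compound 2 to compound 3 all remain of unknown size. Among the compounds with values here, the only evidence is that (the limit of > 100 ug/mL in this assay, at which 1 of the 3 values shown sits), the limit of > 25 ug/mL in this assay, at which 1 of the 3 values shown sits, and the limit of > 40 ug/mL in this assay, at which 1 of the 3 values shown sits, were each reached without a half-maximal value appearing.

Compound 4 `COC(=O)c1cc(-c2cccc(NC(=O)c3ccc(/C=C/C(=O)c4ccc(F)cc4)cc3)c2)on1` differs from compound 3 in one place: 4-fluorophenyl in place of 3-bromophenyl on a carbonyl carbon. Within the data shown here, the steps among compounds 1, 2 and 3 bear on this change only in that each swap of the group on the carbonyl carbon left the reading at a limit; no step of readable size is available. A step of an at least 1.6-fold lower number from compound 3 to compound 4 (0.22 log units; that floor lies within the scatter) is therefore expected, which is to say no step beyond the scatter, and compound 4 is expected to give about 60 ug/mL, between 20 ug/mL and 150 ug/mL, most likely as another limit.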

Compound 4, half-maximal cytotoxic concentration: > 20 ug/mL
Compound 4 ended at the assay's limit; the forecaster's own chance of this, stated with the estimate: 80%; the middle value does not contradict the limit.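

In this assay compound 4 gives > 20 ug/mL, which is a limit of the assay and not a number. Its steps from compound 1, compound 2 and compound 3 cannot be read, as all four readings are limits. The compounds shown leave open each one's true half-maximal cytotoxic concentration, and whether changing the group on the carbonyl carbon alters it at all.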